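From 3-chlorophenyl to 4-methoxyphenyl on the shared core

The compounds below may be only part of what the source reports. "The series", "measured", "known", "first", "only" and "open" are said of these compounds alone.

Measured in a functional assay on NCI-N87 cells (Homo sapiens) for antiproliferative activity, read by CCK-8 assay, with a stated time of 72 h; on this read-out higher numbers stand for weaker inhibition and lower numbers for stronger inhibition:
- compound 1 `Cc1cc(Nc2cc(N3CCN(C)CC3)nc(Nc3ccc(S(N)(=O)=O)cc3)n2)n[nH]1`: 24000 nM
- compound 2 `Cc1cc(Nc2cc(N3CCN(C)CC3)nc(Nc3ccc(Cl)cc3)n2)n[nH]1`: 7470 nM
- compound 3 `Cc1cc(Nc2cc(N3CCN(C)CC3)nc(Nc3cccc(Cl)c3)n2)n[nH]1`: 1770 nM

Compound 3, at 1770 nM, has the lowest number of the three, and its gaps to both others lie beyond the scatter. The next compound is compound 4 `COc1ccc(Nc2nc(Nc3cc(C)[nH]n3)cc(N3CCN(C)CC3)n2)cc1`, which keeps the shared core and carries 4-methoxyphenyl in place of 3-chlorophenyl on a nitrogen on an aromatic ring.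

Among the measured compounds shown here, no measured compound carries a methoxy group, so only indirect evidence is available. The closest comparison is the swap of 4-chlorophenyl for 3-chlorophenyl, a modest step: a 4.2-fold lower number from compound 2 to compound 3 (0.63 log units; beyond the scatter). The larger step, a 14-fold lower number from compound 1 to compound 3 (1.13 log units; beyond the scatter), leads to the same compound from the 4-sulfamoylphenyl compound. Between the two compounds whose group names begin with 4, the numbers also differ: a 3.2-fold lower number from compound 1 to compound 2 (0.51 log units; beyond the scatter). Compound 4 shares that naming with compound 2, which gives 7470 nM, so a modest rise toward weaker inhibition seems likely in this assay. The expected step is a 2.8-fold higher number from compound 3 to compound 4 (0.45 log units; beyond the scatter). For compound 4 the estimated value is 5000 nM, with an expected range of 1800 nM to 14000 nM.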

Compound 4, half-maximal inhibitory concentration: 18900 nM
Beside the measured number, compound 4's estimate is 3.8-fold (0.58 log units) below it; the whole stated range lies below it.
By their numbers in this assay, from the lowest: compound 3; then compound 2; then compounds 4 and 1 (each within the scatter of the next).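

In this assay, replacing 3-chlorophenyl with 4-methoxyphenyl on a nitrogen on an aromatic ring is a large loss, an 11-fold higher number from compound 3 to compound 4 (1.03 log units; beyond the scatter), although this single swap changes both the group on the phenyl ring and where it sits. The methoxy-for-chloro comparison, with the ring position kept, separates part of that loss: it gives a 2.5-fold higher number from compound 2 to compound 4 (0.40 log units; beyond the scatter), whereas methoxy in place of sulfamoyl gives a 1.3-fold lower number from compound 1 to compound 4 (0.10 log units; within the scatter), so compound 1 and compound 4 cannot be told apart. Among the compounds shown here, all three compounds with a group at the 4 position of the phenyl ring now have higher numbers than compound 3, which extends the advantage of 3-chlorophenyl beyond the two earlier comparisons.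

The compounds shown offer no measured explanation for these differences. From the compounds shown here alone, it remains open whether 3-methoxyphenyl would keep the lower number of compound 3, which would tie that number to the ring position rather than to chloro, and how a phenyl ring carrying an amine or a carboxylic acid would behave in this place.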